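Stretching cyclopropyl into a 2-cyclopropylethynyl group

The source may hold more compounds than are shown below. What is called first, only, known or untested is meant among the compounds shown, and "the series" means these compounds.

Within the data shown here, in an ADME assay (liver) for metabolic stability, with Liver microsome (Homo sapiens) as the target, using microsomes and NADPH, with a stated time of 30 min, tested at 1 uM (on this read-out higher numbers stand for fast clearance and lower numbers for slow clearance), compound 3 `Nc1ccc(S(=O)(=O)N2CCN(c3ncc(C(O)(C(F)(F)F)C(F)(F)F)cc3C3CC3)CC2)cn1` gives 38 mL.min-1.g-1 as the only true number among the three measured compounds. Compound 1 `Nc1ccc(S(=O)(=O)N2CCN(c3ncc(C(O)(C(F)(F)F)C(F)(F)F)cc3Br)CC2)cn1` reads < 14 mL.min-1.g-1 and that is a limit of the assay, not a number. Compound 2 `COc1cc(C(O)(C(F)(F)F)C(F)(F)F)cnc1N1CCN(S(=O)(=O)c2ccc(N)nc2)CC1` reads < 14 mL.min-1.g-1 and that too is a limit of the assay.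

The next molecule, compound 4 `Nc1ccc(S(=O)(=O)N2CCN(c3ncc(C(O)(C(F)(F)F)C(F)(F)F)cc3C#CC3CC3)CC2)cn1`, carries 2-cyclopropylethynyl in place of cyclopropyl on an aromatic carbon and so keeps the three-membered ring while adding a triple bond. Among the measured compounds shown here, two measured steps concern this same place. Putting cyclopropyl in place of bromo gave an at least 2.7-fold higher number from compound 1 to compound 3 (0.43 log units; beyond the scatter) and putting it in place of methoxy gave an at least 2.7-fold higher number from compound 2 to compound 3 (0.43 log units; beyond the scatter) as well. Both rest on limits, and neither tests a triple bond. The cyclopropyl ring stays, so the forecast starts from compound 3 at 38 mL.min-1.g-1 and leans only slightly upward. The expected result is a 1.2-fold higher number from compound 3 to compound 4 (0.07 log units; within the scatter) in this assay (an estimate). For compound 4 the estimated clearance is 45 mL.min-1.g-1 (expected range 18 mL.min-1.g-1 to 100 mL.min-1.g-1).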

Compound 4, intrinsic clearance in microsomes: < 14 mL.min-1.g-1
Compound 4 was reported as a limit (the forecaster's own chance of this, stated with the estimate: 10%); middle value at least 3.2-fold (0.50 log units) away from the limit.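

In this assay, extending the group with a triple bond while keeping the three-membered ring gives an at least 2.7-fold lower number from compound 3 to compound 4 (0.43 log units; beyond the scatter), so the ring alone does not fix the clearance at this position. Earlier, cyclopropyl in compound 3 was the only carbon group shown here, and it alone stood clear of the limit; compound 4, also attached through carbon, reads as a limit of the assay and not as a number. The steps to compound 4 from compound 1 and from compound 2 cannot be read, because all three share one limit: the limit of < 14 mL.min-1.g-1 in this assay, at which 3 of the 4 values shown sit.

On these data alone, how far bromo, methoxy and 2-cyclopropylethynyl differ from one another therefore stays open. Also open, as far as these compounds go, is whether the triple bond itself matters or the added length, which a plain propyl chain or an unsubstituted ethynyl group at this place could help separate.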